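Extending the Chain of Compound 1

This account rests on a few compounds, and the source may have more. Where it says the series, first, only, none or still open, it means among the compounds named here.

In a functional assay (Hepatocyte) for inhibition, with Rattus norvegicus as the target (on this read-out lower numbers stand for stronger inhibition and higher numbers for weaker inhibition), compound 1 (`CC(C)(CCCCCCCCCCCCC(C)(C)CC(=O)O)CC(=O)O`) gives 150000 nM as its reading. Compound 2 (`CC(C)(CCCCCCCCCCC(C)(C)CC(=O)O)CC(=O)O`) gives 80000 nM with a different chain length, and compound 3 (`CC(C)(CCCCCCC(C)(C)CC(=O)O)CC(=O)O`) gives 300000 nM with another. Compound 1 lies within the usual scatter of both, and the three values do not follow chain length in any steady way. Compound 4 (`CC(C)(CCCCCCCCCCCCCCC(C)(C)CC(=O)O)CC(=O)O`) is still unmeasured. It carries 3-(carboxymethyl)-3-methylbutyl in place of 1-(carboxymethyl)-1-methylethyl on a saturated chain carbon, ten or more bonds along the chain from a carbonyl carbon. No change beyond the scatter is expected in this assay here. The expected step of no change at the digits printed from compound 1 to compound 4 (within the scatter) is small. Compound 4 is estimated at 150000 nM within a range of 60000 nM to 350000 nM as its likely span.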

Compound 4, half-maximal inhibitory concentration: 300000 nM
The estimate for compound 4 lay 2.0-fold (0.30 log units) below the measured number; the range from low to high includes it.
By their numbers in this assay, from the lowest: compounds 2, 1, 3 and 4 (each within the scatter of the next, the first and the last beyond it).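

In this assay, 3-(carboxymethyl)-3-methylbutyl in place of 1-(carboxymethyl)-1-methylethyl gives a 2.0-fold higher number from compound 1 to compound 4 (0.30 log units; within the scatter) at this place, on a saturated chain carbon. Among the compounds shown here, the earlier compounds showed only shorter chains, so this is the first sign that a chain longer than that of compound 1 still reads within the scatter of compound 1. No supporting data are available to explain this reading. Going by these compounds, whether an ether oxygen or a phenyl ring within the chain, or a tetrazole in place of a carboxylic acid, would give a reading beyond the scatter stays open.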